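The source may report more compounds than this note shows. Statements on the series, on what has been measured and on what is new or still open speak of the compounds shown alone.

Compound 1 `COC(=O)c1cccc(NC(=O)COc2ccc(C(C)(C)CC(C)(C)C)cc2)c1`: 8920 nM
Compound 2 `CCCc1ccc(OCC(=O)Nc2cccc(C(=O)OC)c2)cc1`: > 40000 nM

In an assay on isolated protein for inhibition of malate dehydrogenase, mitochondrial (Homo sapiens), with a stated time of 30 min (a lower number here means a stronger inhibitor, a higher number a weaker inhibitor), compound 1 gives 8920 nM. For compound 2 this assay gives only a limit, > 40000 nM, and no number within its range; this is the limit of > 40000 nM in this assay, at which 1 of the 2 values shown sits, the only limit among the two values shown. Compound 2 therefore stands at the weak end of what is measured, and the step of an at least 4.4-fold higher number from compound 1 to compound 2 (0.65 log units; beyond the scatter) shows how much was lost when the large branched group was cut down.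

Compound 3 `COC(=O)c1cccc(NC(=O)COc2ccc([N+](=O)[O-])cc2)c1` carries the change (nitro in place of propyl on an aromatic carbon). Going by the values given here, the one measured step, an at least 4.4-fold higher number from compound 1 to compound 2 (0.65 log units; beyond the scatter), concerns the same aromatic carbon but swaps between two carbon chains, so it speaks only indirectly to a swap from propyl to nitro. The group entering is as small as the one leaving, and nothing measured here points to a recovery of potency. The expectation for compound 3 in this assay is therefore a step that the limit leaves unreadable from compound 2 to compound 3, meaning no change beyond the scatter, with a high chance that again only a limit is reported. Compound 3 is estimated at 50000 nM, within 12000 nM to 200000 nM.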

Compound 3, half-maximal inhibitory concentration: > 40000 nM
Compound 3: only a limit was reported (the forecaster's own chance of this, stated with the estimate: 70%); the middle value is on the limit's open side.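

Putting nitro in place of propyl, a swap with the same count of heavy atoms but with two hydrogen-bond acceptors entering, does not bring back a readable value in this assay, and compound 3, like compound 2, is reported only as a limit: the limit of > 40000 nM in this assay, at which 2 of the 3 values shown sit. The step between those two compounds cannot be read, so neither group can be ranked above the other at this aromatic carbon. Going by these compounds alone, what can be read is an at least 4.4-fold higher number from compound 1 to compound 3 (0.65 log units; beyond the scatter), so among the three compounds only the one carrying 1,1,3,3-tetramethylbutyl gives a number, and this now holds for a carbon chain and for a nitro group alike.

From the compounds shown here alone, it remains open how much of the large branched group is needed for a readable value to return, and a longer chain such as hexyl, or a smaller branched group such as tert-butyl, on the same aromatic carbon would speak to that. Going by these compounds, it is also open whether a group of a different kind there, such as an amine or a carboxylic acid, would give a number at all in this assay.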